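The source may report more compounds than this note shows. Statements on the series, on what has been measured and on what is new or still open speak of the compounds shown alone.

Of the compounds shown here, three have been measured in an assay for inhibition of protein deacetylase HDAC6 (Homo sapiens) (on this read-out lower numbers stand for stronger inhibition and higher numbers for weaker inhibition), all sharing one core and differing at only two places. Compound 1 `NS(=O)(=O)NCCCC[C@H](NC(=O)OCc1ccccc1)C(=O)Nc1nccs1` gives 4100 nM. For the measured compounds named here, compound 2 `NS(=O)(=O)NCCCC[C@H](NC(=O)OCc1ccccc1)C(=O)Nc1nc(-c2ccc(Cl)cc2)cs1` gives 250 nM, and the single change from compound 1 to compound 2, 4-chlorophenyl in place of hydrogen on an aromatic carbon, brought a 16-fold lower number from compound 1 to compound 2 (1.21 log units; beyond the scatter). Compound 3 `NS(=O)(=O)NCCCC[C@H](NC(=O)OCc1cccc(Cl)c1)C(=O)Nc1nc(-c2ccccc2)cs1` gives 280 nM; it stands second highest of the three numbers, within the scatter of compound 2 and well apart from compound 1.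

The next step leads to compound 4 `NS(=O)(=O)NCCCC[C@H](NC(=O)NCc1ccc(F)cc1)C(=O)Nc1nc(-c2ccccc2)cs1`. Relative to compound 3 the change is (4-fluorobenzyl)amino in place of (3-chlorobenzyl)oxy on a carbonyl carbon; seen one bond further out, a ((3-chlorobenzyl)oxy)carbonyl group becomes a (4-fluorobenzyl)carbamoyl group at the same position. Going by the values given here, no measured step touches this part of the molecule: the only step with a known size, from compound 1 to compound 2, sits on the other end of the core, and compounds 2 and 3 differ at two places at once, so their closeness says little about either change alone. With nothing to lean on, the expected step of a 1.3-fold higher number from compound 3 to compound 4 (0.10 log units; within the scatter) is none beyond the scatter, and the wide range reflects that uncertainty. For compound 4 the estimate in this assay is 350 nM, between 100 nM and 1500 nM.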

Compound 4, half-maximal inhibitory concentration: 370 nM
Compound 4: middle estimate off by 1.1-fold (0.02 log units), on the low side; the range from low to high includes it.
By their numbers in this assay, from the lowest: compounds 2, 3 and 4 (each within the scatter of the next); then compound 1.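

In this assay, the swap of (3-chlorobenzyl)oxy for (4-fluorobenzyl)amino on the carbonyl carbon gives a 1.3-fold higher number from compound 3 to compound 4 (0.12 log units; within the scatter), so this position accepts a real change of group without a measurable shift in the read-out. The change is not a small one: oxygen gives way to nitrogen as the atom linking the benzyl group to the carbonyl, a hydrogen-bond donor enters, and chlorine gives way to fluorine, while the heavy-atom count and the aromatic ring stay as they were. Nothing measured here says what lies behind this result.

On these data alone, since the linking atom and the halogen changed in one step, their separate contributions stay unknown, and opposing effects that happen to cancel cannot be told from two changes that each do little; a (3-chlorobenzyl)amino group on the same carbonyl carbon would separate them. Also open, as far as these compounds go, is how much of this end the read-out needs, for instance whether a simple methylamino group without the aromatic ring, or a longer chain such as (2-phenylethyl)amino, would leave the number in the same range.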